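Swapping furan-2-yl for phenyl in compound 1

The source may report more compounds than this note shows. Statements on the series, on what has been measured and on what is new or still open speak of the compounds shown alone.

Compound 1 `COc1cc(/C=C/C(=O)/C=C/c2ccco2)ccc1OCc1cn(CCCOc2cc(=O)oc3ccccc23)nn1` has been tested in a functional assay on COLO 205 cells (Homo sapiens) for inhibition, read by sulforhodamine B assay, with a stated time of 48 h, tested at 50 uM (on this read-out higher numbers stand for more inhibition of growth at the one concentration tested and lower numbers for less inhibition of growth), where compound 1 gives 59%. Among the compounds with values here, that is the middle of the three numbers available so far. Compound 2 `COc1ccc(/C=C/C(=O)/C=C/c2ccc(OCc3cn(CCOc4cc(=O)oc5ccccc45)nn3)c(OC)c2)cc1OC` reaches 80% and compound 3 `COc1cc(/C=C/C(=O)/C=C/c2cccs2)ccc1OCc1cn(CCCCOc2cc(=O)oc3ccccc23)nn1` gives 40%, and both gaps to compound 1 lie beyond the usual scatter. These three compounds differ from one another in more than one place, so neither gap can be traced to a single change.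

Compound 4 `COc1cc(/C=C/C(=O)/C=C/c2ccccc2)ccc1OCc1cn(CCCOc2cc(=O)oc3ccccc23)nn1` has not yet been measured. It keeps the core of compound 1 and changes one group: phenyl in place of furan-2-yl on a double-bonded chain carbon bound to a double-bonded chain carbon. In words, phenyl takes the place of furan-2-yl on a double-bonded chain carbon bound to a double-bonded chain carbon. Within the data shown here, no measured pair shows this swap on its own, so the expectation stays anchored on compound 1 at 59%. In this assay no shift beyond the scatter is expected, and the estimated change is a number 3 percentage points lower from compound 1 to compound 4 (within the scatter). The estimate for compound 4 is 56%, with an expected range from 36% to 76%.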

Compound 4, percent growth inhibition at one concentration: 43%
Estimate against measurement, compound 4: 13 percentage points above; low and high end bracket the measured number.
By their numbers in this assay, from the lowest: compounds 3 and 4 (each within the scatter of the next); then compound 1; then compound 2.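

In this assay, within the data shown here, phenyl in place of furan-2-yl gives a number 16 percentage points lower from compound 1 to compound 4 (beyond the scatter) and so provides the only comparison here in which a single group changes. Among these compounds, it shows that the group at this place, on a double-bonded chain carbon bound to a double-bonded chain carbon, affects growth inhibition even when the rest of the molecule stays the same, which the earlier compounds, differing in more than one place, could not show. Nothing measured here says why the number falls.

Going by these compounds, whether an amine or a carboxylic acid at this place would raise, lower or keep the number remains open. Among the compounds shown here, it is also unknown whether the same swap would give a similar step on a longer chain than the one in compound 1.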